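Swapping an Amide for Nitro on a Shared Core

The source may hold more compounds than are shown below. What is called first, only, known or untested is meant among the compounds shown, and "the series" means these compounds.

Of the compounds shown here, two of a shared design have been measured in an assay on microsomes from brain for inhibition of Fatty-acid amide hydrolase 1 (Rattus norvegicus), read by fluorescence and HPLC, with a stated time of 45 min; on this read-out higher numbers stand for weaker inhibition and lower numbers for stronger inhibition. Compound 1, `N#CNC(COc1ccc(Oc2ccccc2)cc1)Cn1ncnn1`, gives 5300 nM in this assay. Compound 2, `COCC(=O)Nc1ccc2c(cnn2CC(=O)COc2ccc(Oc3ccccc3)cc2)c1`, gives 6300 nM in this assay, a number that sits alongside that of compound 1, the gap between the two lying within the scatter of repeated measurements. Compound 3, `O=C(COc1ccc(Oc2ccccc2)cc1)Cn1ncc2cc([N+](=O)[O-])ccc21`, has not yet been measured. It differs from compound 2 in one place: nitro in place of ((methoxymethyl)carbonyl)amino on an aromatic carbon. Among the compounds with values here, no measured pair shows this particular exchange, so there is no step to lean on. The expectation is that the change from compound 2 to compound 3 is a 1.4-fold lower number from compound 2 to compound 3 (0.15 log units; within the scatter), a modest shift at most, with no strong reason to expect a move beyond the scatter in either direction. Compound 3 is therefore estimated at 4500 nM in this assay, within a range from 1200 nM to 18000 nM.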

Compound 3, half-maximal inhibitory concentration: 550 nM
Compound 3: middle estimate off by 8.2-fold (0.91 log units), on the high side; the whole stated range lies above it.
By their numbers in this assay, from the lowest: compound 3; then compounds 1 and 2 (each within the scatter of the next).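

The group on this aromatic carbon of the shared core clearly matters in this assay: putting nitro in place of ((methoxymethyl)carbonyl)amino gives an 11-fold lower number from compound 2 to compound 3 (1.06 log units; beyond the scatter), a large step. Compounds 1 and 2 differ in more than one place, so their similar numbers said nothing about this position on its own. The exchange also removes a hydrogen-bond donor and shortens the substituent, but no available evidence explains the step.

This single exchange cannot separate the loss of ((methoxymethyl)carbonyl)amino from the arrival of nitro, so either could account for the step. It also leaves open how an amine, a carboxylic acid or a simple acetylamino group on this same aromatic carbon would compare with compound 3.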